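The source may hold more compounds than are shown below. What is called first, only, known or untested is meant among the compounds shown, and "the series" means these compounds.

Measured compounds:
compound 1, `CC(C)n1nc(-c2cc(C3CCCCC3)on2)c2c(N)ncnc21`, giving 910 nM in an assay on isolated protein for inhibition of proto-oncogene tyrosine-protein kinase receptor Ret (Homo sapiens), read by radiometric assay and 33P incorporation, in the presence of a further agent that is not named here; a higher number here means a weaker inhibitor, a lower number a stronger inhibitor
compound 2, `Nc1ncnc2c1c(-c1cc(C3CC3)on1)nn2C1CCCCC1`, giving 2 nM in this assay
compound 3, `CC(C)(O)Cn1nc(-c2cc(C3CC3)on2)c2c(N)ncnc21`, giving 68 nM in this assay

Compound 3 stands second highest of the three numbers in this assay: compound 1 lies above it, and compound 2 below it, both beyond the scatter. Among the measured compounds shown here, the one single-place step known here runs from compound 2 to compound 3, a 34-fold higher number from compound 2 to compound 3 (1.53 log units; beyond the scatter), where a saturated ring on the aromatic nitrogen gave way to a chain carrying a hydroxyl.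

Compound 4, `CCCCCCCn1nc(-c2cc(C3CC3)on2)c2c(N)ncnc21`, differs from compound 3 in one place: hexyl in place of 1-hydroxy-1-methylethyl on a saturated chain carbon bound to an aromatic nitrogen. The hydroxyl and its carbon thus leave, and a plain chain of the kind seen to fare well as cyclohexyl in compound 2 takes its place. For the measured compounds named here, that earlier step is the only one bearing on this change, and it was large. He therefore expects the number to fall beyond the scatter, though not all the way back to compound 2, since a flexible chain is not a ring. His estimate for compound 4 is 20 nM, between 5 nM and 100 nM, which means an expected step of a 3.4-fold lower number from compound 3 to compound 4 (0.53 log units; beyond the scatter).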

Compound 4, half-maximal inhibitory concentration: 96 nM
For compound 4 the middle estimate is 4.8-fold (0.68 log units) below the measured one, within the range that was stated.
By their numbers in this assay, from the lowest: compound 2; then compounds 3 and 4 (each within the scatter of the next); then compound 1.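

The step of a 1.4-fold higher number from compound 3 to compound 4 (0.15 log units; within the scatter) shows that, in this assay, heptyl and 2-hydroxy-2-methylpropyl on the aromatic nitrogen cannot be told apart, so among these compounds the presence of the hydroxyl makes no readable difference at this position. The step of a 48-fold higher number from compound 2 to compound 4 (1.68 log units; beyond the scatter) shows that a plain chain without the hydroxyl also stands well apart from cyclohexyl, so among compounds 2, 3 and 4 the low number goes with the ring alone. Nothing available explains this difference between ring and chain.

On these data alone, whether a ring as such is enough remains open, and cyclopentyl or cycloheptyl on the aromatic nitrogen would test this. As far as these compounds go, how a shorter chain such as ethyl, or a chain carrying an amine, would compare with heptyl also remains open.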